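Trimming the cyclohexyl side chain of compound 3

The compounds below may be only part of what the source reports. "The series", "measured", "known", "first", "only" and "open" are said of these compounds alone.

In a functional assay on MES-SA cells (Homo sapiens) for cytotoxicity, read by luminescence and CellTiter-Glo, with a stated time of 72 h (on this read-out lower numbers stand for stronger inhibition and higher numbers for weaker inhibition), compound 1 `COC[C@H](NC(=O)c1cc(OC)no1)C(=O)N[C@@H](COC)C(=O)N[C@@H](CC(C)C)C(=O)[C@@]1(C)CO1` gives 12 nM, compound 2 `CC[C@H](NC(=O)[C@H](COC)NC(=O)c1cc(C)on1)C(=O)N[C@@H](CC(C)C)C(=O)[C@@]1(C)CO1` gives 92 nM and compound 3 `COC[C@H](NC(=O)c1cc(C)on1)C(=O)N[C@@H](CC1CCCCC1)C(=O)N[C@@H](CC(C)C)C(=O)[C@@]1(C)CO1` gives 210 nM, the highest of the three numbers. Compound 4 `COC[C@H](NC(=O)c1cc(C)on1)C(=O)N[C@@H](CC(C)C)C(=O)N[C@@H](CC(C)C)C(=O)[C@@]1(C)CO1` differs from compound 3 as follows: isopropyl in place of cyclohexyl on a saturated chain carbon, two bonds along the chain from an amide-type nitrogen and a carbonyl carbon. Going by the values given here, the one measured step at this place is a 2.3-fold higher number from compound 2 to compound 3 (0.36 log units; beyond the scatter), a modest rise on going from methyl to cyclohexyl. Among the compounds with values here, compound 1 offers no direct guide, since it has no measured step at this place. Isopropyl is a smaller group than cyclohexyl but larger than methyl, so a partial reversal of that step is expected: a small move to a lower number in this assay. The expected change is a 1.9-fold lower number from compound 3 to compound 4 (0.28 log units; within the scatter). For compound 4 the estimate is 110 nM, with an expected range from 40 nM to 280 nM.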

Compound 4, half-maximal inhibitory concentration: 45 nM
Compound 4: middle estimate off by 2.4-fold (0.39 log units), on the high side; measured number inside the range.
By their numbers in this assay, from the lowest: compound 1; then compound 4; then compound 2; then compound 3.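

In this assay, replacing cyclohexyl with isopropyl at this place gives a 4.7-fold lower number from compound 3 to compound 4 (0.67 log units; beyond the scatter), a larger drop than the reversal of the earlier rise alone would imply, and replacing methyl with isopropyl gives a 2.0-fold lower number from compound 2 to compound 4 (0.31 log units; beyond the scatter). Isopropyl therefore stands below both other groups, so the number does not rise steadily with group size across these three compounds. No supporting data bear on the reason for this order.

Whether branching itself matters stays open, since a straight propyl chain and tert-butyl are not among the compounds shown. A side chain carrying an amine or a carboxylic acid is also absent.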